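A few compounds are considered here, and "the series" means these few. Any claim that something is new, unique, unknown or untested is made for them only; others in the source may bear on it.

Working notes on the series. Of the compounds shown here, two with the shared core have a number so far. Compound 1 `Cc1nc2c([nH]1)C(=O)/C(=N/c1ccc(F)cc1)C(Cl)=C2O` gives 1000 nM in a functional assay on HUVEC cells (Homo sapiens) for antiproliferative activity; on this read-out lower numbers stand for stronger inhibition and higher numbers for weaker inhibition. Compound 2 `Cc1nc2c([nH]1)C(=O)/C(=N/c1cccc(Cl)c1Cl)C(Cl)=C2O` gives 300 nM in this assay, the lower of the two numbers, and the gap to compound 1 lies beyond the scatter. Compound 3 `Cc1nc2c([nH]1)C(=O)/C(=N/c1cccc(Cl)c1)C(Cl)=C2O` is not yet measured. It is derived from compound 2 by hydrogen in place of chloro on an aromatic carbon, the leaving chloro standing ortho to a chloro group and ortho to a large group. For the measured compounds named here, no measured pair shows this change directly, so the size of the step is open. Since the loss of one chloro moves compound 3 part of the way toward the substitution pattern of compound 1, a modest weakening relative to compound 2 is expected, but possibly within the scatter. The estimate for compound 3 is 500 nM, in the range 200 nM to 1500 nM, which means an expected step of a 1.7-fold higher number from compound 2 to compound 3 (0.22 log units; within the scatter).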

Compound 3, half-maximal inhibitory concentration: 600 nM
For compound 3 the middle estimate is 1.2-fold (0.08 log units) below the measured one, and the stated range covers the measured number.
By their numbers in this assay, from the lowest: compounds 2, 3 and 1 (each within the scatter of the next, the first and the last beyond it).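

In this assay, for the compounds shown here, the change of hydrogen in place of chloro on an aromatic carbon, ortho to a chloro group and ortho to a large group, gives a 2.0-fold higher number from compound 2 to compound 3 (0.30 log units; within the scatter) and is the first direct reading at this position. The step lies within the scatter, so the second chloro of compound 2 is not shown to matter at this position. The change of 3-chlorophenyl in place of 4-fluorophenyl on a double-bonded nitrogen gives a 1.7-fold lower number from compound 1 to compound 3 (0.22 log units; within the scatter) and also stays within the scatter, so neither single change separates its two compounds on this read-out.

Still open, from the compounds shown here alone, is whether a methoxy group, an amine or a carboxylic acid at this position would give a step beyond the scatter. Nothing at hand gives a cause for either step.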